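The source may report more compounds than this note shows. Statements on the series, on what has been measured and on what is new or still open speak of the compounds shown alone.

Measured compounds and their values in a functional assay on PC-3 cells (Homo sapiens) for inhibition, read by sulforhodamine B assay, with a stated time of 48 h; on this read-out higher numbers stand for lower toxicity in this test and lower numbers for higher toxicity in this test:

Compound 1 `COc1cc(-c2nn(-c3cccc(NC(=O)Nc4ccc(Cl)c(Cl)c4)c3)cc2-c2ccncc2)ccc1Cl`: in this assay compound 1 gives > 50000 nM, which is a limit of the assay.

Compound 2 `O=C(Nc1cccc(-n2cc(-c3ccncc3)c(-c3ccc(Cl)c(O)c3)n2)c1)Nc1ccc(Cl)c(Cl)c1`: in this assay compound 2 gives > 32500 nM, again a limit of the assay.

Compound 1 therefore stands only at a limit; the other value shown is a limit as well, at the limit of > 32500 nM in this assay, at which 1 of the 2 values shown sits, and (the limit of > 50000 nM in this assay, at which 1 of the 2 values shown sits). For the measured compounds named here, the single measured step, hydrogen in place of methyl on an oxygen on an aromatic ring, reads a step that the two limits leave unreadable from compound 1 to compound 2, so its size is not known.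

Compound 3 `COc1cc(-c2nn(-c3cccc(NC(=O)Nc4ccc(Cl)c(C(F)(F)F)c4)c3)cc2-c2ccncc2)ccc1Cl` differs from compound 1 by trifluoromethyl in place of chloro on an aromatic carbon. Going by the values given here, no measured step touches this part of the structure, and the one step that exists is unreadable, so nothing points to a shift beyond the scatter. Compound 3 is expected to sit near the same limit in this assay, with an estimated step of a number no higher from compound 1 to compound 3 (the limit leaves the size open) and an estimate of 50000 nM, ranging from 15000 nM to 100000 nM.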

Compound 3, concentration lethal to 50% of the cells: > 32500 nM
Compound 3: a limit, no number (the forecaster's own chance of this, stated with the estimate: 75%); the middle value does not contradict the limit.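

In this assay compound 3 gives > 32500 nM, which is a limit of the assay. For the compounds shown here, compound 1 and compound 3 are both known only as limits, so no step between them can be read. The compounds shown leave open whether trifluoromethyl in place of chloro changes the lethal concentration at all.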